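Bromo for Chloro in Two Related Series

The source may report more compounds than this note shows. Statements on the series, on what has been measured and on what is new or still open speak of the compounds shown alone.

Compound 1 `O=C1/C(=C/c2ccc(Cl)cc2)Cc2ccccc21` sits at a limit of the assay: > 500000 nM
Compound 2 `O=C1/C(=C/c2ccc(Br)cc2)Cc2ccccc21` sits at a limit of the assay: > 500000 nM
Compound 3 `O=C1/C(=C/c2cccc(Cl)c2)CCCc2ccccc21` gives a number: 23800 nM

In a functional assay on MOLT-4 cells (Homo sapiens) for inhibition (on this read-out higher numbers stand for weaker inhibition and lower numbers for stronger inhibition), compound 1 reaches only a limit of the assay, > 500000 nM. The same holds for compound 2, whose result in this assay is likewise a limit, > 500000 nM. Between them lies one change, (bromo in place of chloro on an aromatic carbon), and the step that the two limits leave unreadable from compound 1 to compound 2; its size cannot be read because of the limit of > 500000 nM in this assay, at which 2 of the 3 values shown sit. Going by the values given here, compound 3 is the one compound with a number, 23800 nM in this assay. How its core differs from the core of compound 1 is not broken down here.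

Compound 4 `O=C1/C(=C/c2cccc(Br)c2)CCCc2ccccc21` has not yet been measured. It differs from compound 3 by bromo in place of chloro on an aromatic carbon. Among the compounds with values here, this is the same kind of change as the one from compound 1 to compound 2, but the place differs: in the measured pair the halogen stands para to a large group, in the new pair it stands meta to a large group. Since the measured step gives no readable size, the expectation for the step of a 1.2-fold lower number from compound 3 to compound 4 (0.08 log units; within the scatter) rests only on the small size of the change counted under the difference, and is an estimate. Compound 4 is therefore expected to give about 20000 nM in this assay, somewhere between 7000 nM and 60000 nM.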

Compound 4, half-maximal inhibitory concentration: 17100 nM
For compound 4 the middle estimate is 1.2-fold (0.07 log units) above the measured one, and the stated range covers the measured number.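

In this assay, with bromo in place of chloro meta to a large group, the result is a 1.4-fold lower number from compound 3 to compound 4 (0.14 log units; within the scatter), so the two compounds cannot be told apart and, on this core, the two halogens read alike. On the core of compound 1, the same kind of change gives no readable step, since compound 1 and compound 2 each stand only at a limit of the assay: the limit of > 500000 nM in this assay, at which 2 of the 4 values shown sit. Going by these compounds alone, the one readable pair therefore does not show that the result carries from one core to the other, as it gives no size for the step on the core of compound 1, and the halogen stands in a different place in the two pairs.

From the compounds shown here alone, all four compounds carry chloro or bromo, so it remains open whether a different group on the aromatic carbon, such as a methoxy group, an amine or a carboxylic acid, would give a step beyond the scatter on the core of compound 3. Going by these compounds, it also remains open how the core of compound 1 would read with its halogen meta to a large group, which would separate the role of the core from that of the place.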